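Vinyl in Place of But-3-yn-1-yl on a Chain

The source may hold more compounds than are shown below. What is called first, only, known or untested is meant among the compounds shown, and "the series" means these compounds.

Among the measured compounds shown here, only one compound in this small set carries a number. In a functional assay on U-373MG ATCC cells (Homo sapiens) for inhibition, read by colorimetric assay and MTT assay, with a stated time of 72 h (on this read-out lower numbers stand for stronger inhibition and higher numbers for weaker inhibition), compound 1 (`C=CCCCCOc1ccccc1-c1cnc(OCCC=C)n1C`) gives a half-maximal value of 33000 nM (the sole measured figure). For compound 2 (`CCCCOc1ncc(-c2ccccc2OC)n1C`) the entry reads "not determined" (no result reported) (no result). For compound 3 (`C#CCCCCOc1ncc(-c2ccccc2OC)n1C`) the entry also reads "not determined" (no result reported) (no result), so compound 3 has no position on the scale and stands alongside compound 2 as a gap in the data.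

The next compound is compound 4 (`C=CCCOc1ncc(-c2ccccc2OC)n1C`). The structural change leading to it is vinyl in place of but-3-yn-1-yl on a saturated chain carbon, two bonds along the chain from an oxygen on an aromatic ring.

For the measured compounds named here, no measured step exists to serve as a guide. In this assay the expectation therefore rests on the level of compound 1 (33000 nM), with no direction assigned.

Compound 4 is expected at an estimated 30000 nM (with an expected range from 10000 nM to 90000 nM).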

Compound 4, half-maximal inhibitory concentration: 16000 nM
Estimate against measurement, compound 4: 1.9-fold (0.27 log units) above; the measured number falls inside the stated range.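

In this assay, the set now holds its first readable step, a 2.1-fold lower number from compound 1 to compound 4 (0.31 log units; beyond the scatter), a modest change that lies beyond the scatter, with hydrogen in place of pent-4-en-1-yl on a saturated chain carbon bound to an oxygen on an aromatic ring. The number thus drops when that chain is removed, a direction the earlier entries could not show, whereas the change of but-3-yn-1-yl to vinyl cannot be read, as compound 3 has no number. Nothing in the data shown accounts for the step.

The compounds shown leave open how an amine or a carboxylic acid at the end of the chain on the saturated carbon would read. They also leave open whether a longer chain carrying a nitrile would follow the same direction.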